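Working notes on cell tolerance in a shared-core series

This account rests on a few compounds, and the source may have more. Where it says the series, first, only, none or still open, it means among the compounds named here.

Measured so far:
compound 1, `Nc1cc(N)c2nc(-c3ccccc3)c(NCc3ccc(Cl)c(Cl)c3)nc2c1`, 34700 nM
compound 2, `Nc1cc(N)c2nc(-c3ccccc3)c(Oc3ccc(F)cc3)nc2c1`, 83200 nM

In a functional assay on SK-MEL-5 cells (Homo sapiens) for inhibition, read by sulforhodamine B assay, with a stated time of 48 h (a lower number here means that less compound is tolerated, a higher number that more compound is tolerated), compound 1 gives 34700 nM, the lowest of the two numbers. Compound 2 gives 83200 nM, a gap from compound 1 that lies beyond the scatter.

Compound 3, `COc1ccc(CNc2nc3cc(N)cc(N)c3nc2-c2ccccc2)cc1`, differs from compound 1 by 4-methoxyphenyl in place of 3,4-dichlorophenyl on a saturated chain carbon bound to a nitrogen on an aromatic ring. Among the measured compounds shown here, no measured pair shows this change, so its effect is not known from the numbers. A modest upward step is expected, a 1.6-fold higher number from compound 1 to compound 3 (0.20 log units; within the scatter), near or slightly beyond the scatter. Compound 3 is therefore estimated at 55000 nM, with a range from 18000 nM to 160000 nM.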

Compound 3, concentration lethal to 50% of the cells: 56200 nM
The estimate for compound 3 lay 1.0-fold (0.01 log units) below the measured number; the range from low to high includes it.
By their numbers in this assay, from the lowest: compounds 1, 3 and 2 (each within the scatter of the next, the first and the last beyond it).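

In this assay, 4-methoxyphenyl in place of 3,4-dichlorophenyl on a saturated chain carbon bound to a nitrogen on an aromatic ring gives a 1.6-fold higher number from compound 1 to compound 3 (0.21 log units; within the scatter), so this exchange leaves the number within the scatter. The two chlorine atoms can thus give way to a methoxy group here without a readable change. Nothing available explains this result.

Among the compounds shown here, the single step does not separate losing the chlorine atoms from gaining the methoxy group. Also open, going by these compounds, is whether an amine or a carboxylic acid on the phenyl ring would move the number beyond the scatter.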